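Compound 1 to compound 3: nitro for carbamoyl

This account rests on a few compounds, and the source may have more. Where it says the series, first, only, none or still open, it means among the compounds named here.

Measured in an in vitro ADME assay on microsomes from liver (Homo sapiens) for metabolic stability, tested at 1 uM; a higher number here means faster removal of the compound, a lower number slower removal:
- compound 1 `Cc1cc(/C=C/C#N)cc(C)c1Oc1cc(Nc2ccc(C#N)cc2)c(N)cc1C(N)=O` gives 200 mL.min-1.g-1
- compound 2 `CNC(=O)c1cc(N)c(Nc2ccc(C#N)cc2)cc1Oc1c(C)cc(CCC#N)cc1C` gives 120 mL.min-1.g-1

Compound 1 and compound 2 lie within the usual scatter of each other, so these two numbers do not separate them. Among the compounds with values here, no measured pair in this set differs in one place only, so the data hold no direct precedent for the change considered here.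

The next compound is compound 3 `Cc1cc(/C=C/C#N)cc(C)c1Oc1cc(Nc2ccc(C#N)cc2)c(N)cc1[N+](=O)[O-]`, which keeps the core of compound 1 and carries one change: nitro in place of carbamoyl on an aromatic carbon. This is nitro in place of carbamoyl on an aromatic carbon, para to a (4-cyanophenyl)amino group. Within the data shown here, with no measured precedent for this exchange, no step beyond the scatter is expected in this assay, and neither direction is favoured. The expectation therefore stays anchored on compound 1 at 200 mL.min-1.g-1. The estimate amounts to a 1.1-fold lower number from compound 1 to compound 3 (0.05 log units; within the scatter), an expected step inside the scatter. The estimated value for compound 3 is 180 mL.min-1.g-1, with an expected range from 80 mL.min-1.g-1 to 400 mL.min-1.g-1.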

Compound 3, intrinsic clearance in microsomes: 150 mL.min-1.g-1
For compound 3 the middle estimate is 1.2-fold (0.08 log units) above the measured one; low and high end bracket the measured number.
By their numbers in this assay, from the lowest: compounds 2, 3 and 1 (each within the scatter of the next).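

In this assay, nitro in place of carbamoyl on an aromatic carbon, para to a (4-cyanophenyl)amino group, gives a 1.3-fold lower number from compound 1 to compound 3 (0.12 log units; within the scatter). Within the data shown here, this is the first pair that differs in one place only, and it shows that this exchange at this position does not separate the two compounds in this read-out. Carbamoyl has 1 hydrogen-bond donor and nitro has 0 hydrogen-bond donors, with 3 heavy atoms in each group, so in this pair losing the donor comes with no step beyond the scatter, and no measured evidence here bears on the reason for that result.

The series still leaves open whether a group of a different kind on the same aromatic carbon, such as a carboxylic acid, a primary amine or a longer chain, would give a step beyond the scatter. Going by these compounds, with a single pair on the core of compound 1, it also remains open whether nitro in place of carbamoyl would read the same way on another core.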